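From a Sulfonamide Back to a Pyrazole

A few compounds are considered here, and "the series" means these few. Any claim that something is new, unique, unknown or untested is made for them only; others in the source may bear on it.

Compound 1: `Cc1n[nH]cc1-c1cccc2c1CCC2c1ncc[nH]1`; 902 nM
Compound 2: `CCCS(=O)(=O)Nc1cccc2c1CCC2c1ncc[nH]1`; > 10000 nM
Compound 3: `c1cc(-c2ccn[nH]2)c2c(c1)C(c1ncc[nH]1)CC2`; not yet measured

Two compounds share a core and differ only in the group on one aromatic carbon. In a functional assay on CHO cells for agonist activity at Alpha-1B adrenergic receptor (Homo sapiens), read by FLIPR and calcium flux (a higher number here means that more compound is needed for the effect, a lower number that less compound is needed), compound 1 gives 902 nM. For compound 2 only a limit of the assay is known: in this assay compound 2 gives > 10000 nM, which is a limit and not a number (the limit of > 10000 nM in this assay, at which 1 of the 2 values shown sits). Within the data shown here, the single measured step, an at least 11-fold higher number from compound 1 to compound 2 (1.04 log units; beyond the scatter), followed the exchange of a pyrazole for a sulfonamide.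

Compound 3 reverses that kind of exchange: 1H-pyrazol-5-yl in place of (propylsulfonyl)amino on an aromatic carbon. The group entering is an aromatic pyrazole, though attached through a different ring position than in compound 1 and lacking its methyl. Since the step from compound 1 to compound 2 was large and went toward a higher number, the step from compound 2 to compound 3 is expected to be large in the opposite direction, roughly an at least 6.6-fold lower number from compound 2 to compound 3 (0.82 log units; beyond the scatter). Compound 3 is estimated at 1500 nM, with a range from 400 nM to 6000 nM.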

Compound 3, half-maximal effective concentration: 600 nM
The estimate for compound 3 lay 2.5-fold (0.40 log units) above the measured number, and the stated range covers the measured number.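

In this assay, an at least 16-fold lower number from compound 2 to compound 3 (1.22 log units; beyond the scatter), so the drop seen with (propylsulfonyl)amino on this aromatic carbon is not tied to one particular pyrazole: a second pyrazole, attached differently and without the methyl, also gives a measurable response. The true size of that step remains unknown, since compound 2 carries a limit of the assay and not a number: the limit of > 10000 nM in this assay, at which 1 of the 3 values shown sits.

The two pyrazoles themselves cannot be told apart here, with a 1.5-fold lower number from compound 1 to compound 3 (0.18 log units; within the scatter), so 3-methyl-1H-pyrazol-4-yl and 1H-pyrazol-5-yl serve about equally well at this position.

Compound 1 and compound 3 differ in both the methyl and the point of attachment, so the shown compounds leave open whether these two changes each have no effect or instead offset one another. From the compounds shown here alone, it also remains open whether the pyrazole is needed at all, or whether a plain phenyl ring, an amine or a sulfonamide with a methyl in place of the propyl chain would respond like the pyrazoles or like compound 2.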